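Swapping the aryl group at the pyrazole carbon of compound 1

This account rests on a few compounds, and the source may have more. Where it says the series, first, only, none or still open, it means among the compounds named here.

Compound 1 `COc1cc(-c2c(C)nn(-c3nc(-c4ccc(Cl)c(Cl)c4)c(SC(C)C)s3)c2C(=O)O)cc(C(F)(F)F)c1` is the more potent of the two measured compounds: in a functional assay on BJAB cells (Homo sapiens) for antiproliferative activity, with a stated time of 4 days (on this read-out lower numbers stand for an effect already at smaller amounts and higher numbers for an effect only at larger amounts of compound), compound 1 gives 1380 nM. Compound 2 `COc1cncc(-c2c(C)nn(-c3nc(-c4ccc(Cl)c(Cl)c4)c(SC(C)C)s3)c2C(=O)O)c1` carries a 5-methoxypyridin-3-yl in place of the 3-methoxy-5-(trifluoromethyl)phenyl, and in this assay compound 2 gives 21000 nM, which is a 15-fold higher number from compound 1 to compound 2 (1.18 log units; beyond the scatter).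

Compound 3 `Cc1nn(-c2nc(-c3ccc(Cl)c(Cl)c3)c(SC(C)C)s2)c(C(=O)O)c1-c1cccc(Cl)c1C` differs from compound 1 as follows: 3-chloro-2-methylphenyl in place of 3-methoxy-5-(trifluoromethyl)phenyl on an aromatic carbon. Going by the values given here, the only measured step, from compound 1 to compound 2, shows that this position responds strongly to a change of the aryl group, but the change to compound 3 is of a different kind, since a carbon-only ring without acceptors stays in place. Among the compounds with values here, no measured step mirrors it. Compound 3 is therefore expected to stay near compound 1, with a step of a 1.4-fold higher number from compound 1 to compound 3 (0.16 log units; within the scatter), and its estimated value is 2000 nM (range 600 nM to 7000 nM).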

Compound 3, half-maximal effective concentration: 5100 nM
Compound 3: middle estimate off by 2.6-fold (0.41 log units), on the low side; the range from low to high includes it.
By their numbers in this assay, from the lowest: compound 1; then compound 3; then compound 2.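

In this assay the move to 3-chloro-2-methylphenyl loses ground even though the ring remains carbon-only, with a 3.7-fold higher number from compound 1 to compound 3 (0.57 log units; beyond the scatter). This shows that keeping a carbon-only ring at this position does not by itself hold the number of compound 1. The same group still does better than the 5-methoxypyridin-3-yl, with a 4.1-fold lower number from compound 2 to compound 3 (0.61 log units; beyond the scatter), so the three aryl groups give a graded order rather than a simple split into one that works and one that fails, and nothing available explains that order.

The compounds shown leave open whether the methoxy or the trifluoromethyl accounts for the lead of compound 1, as the entering group replaces both at once. They also leave open how an amine, a nitrile or a longer alkoxy chain on this aryl ring would read in this assay.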